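Aryl group on the ring nitrogen: a fourth analogue

A few compounds are considered here, and "the series" means these few. Any claim that something is new, unique, unknown or untested is made for them only; others in the source may bear on it.

Going by the values given here, compound 1 `CCc1ccc(-n2nc(-c3ccc(C(F)(F)F)cc3O)nc2-c2ccccc2O)cc1` gives 107% in a functional assay on PC-12 cells (Rattus norvegicus) for cytotoxicity, read by MTT assay, with stated times of 2 h and 24 h, tested at 10 uM (on this read-out higher numbers stand for a stronger effect at the one concentration tested and lower numbers for a weaker effect), the highest of the three numbers measured so far. Compound 2 `Oc1cc(C(F)(F)F)ccc1-c1nc(-c2ccccc2O)n(-c2ccc(Cl)cc2)n1` gives 96.1% in this assay, and compound 3 `Oc1cc(C(F)(F)F)ccc1-c1nc(-c2ccccc2O)n(-c2cccc(Cl)c2)n1` gives 100%. Of the three steps between them, only a number 10.9 percentage points lower from compound 1 to compound 2 (beyond the scatter) lies beyond the scatter; a number 7 percentage points lower from compound 1 to compound 3 (within the scatter) and a number 3.9 percentage points higher from compound 2 to compound 3 (within the scatter) both stay within it. Compound 1 thus sits at the top of the set only against compound 2, while its gap to compound 3 is not a real difference.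

Compound 4 `Cc1cc(C)cc(-n2nc(-c3ccc(C(F)(F)F)cc3O)nc2-c2ccccc2O)c1` is the next member to be tested in this assay. It differs from compound 1 by 3,5-dimethylphenyl in place of 4-ethylphenyl on an aromatic nitrogen. Among the compounds with values here, the step that bears most directly on it is the one from compound 1 to compound 3, which also exchanges the aryl group on the ring nitrogen and stayed within the scatter. The step from compound 2 to compound 3, another exchange at that position, was likewise within the scatter. On this basis no movement beyond the scatter is expected for compound 4, and the step of a number 6 percentage points lower from compound 1 to compound 4 (within the scatter) is estimated to be small. Compound 4 is expected to give about 101% in this assay, within a range from 88% to 112%.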

Compound 4, a percentage reported as activity, at one concentration (the size of the read-out at that concentration, not a potency): 105%
Compound 4: middle estimate off by 4 percentage points, on the low side, and the stated range covers the measured number.
By their numbers in this assay, from the lowest: compounds 2, 3, 4 and 1 (each within the scatter of the next, the first and the last beyond it).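

Exchanging 4-ethylphenyl for 3,5-dimethylphenyl on the aromatic nitrogen keeps the same eight carbons in the aryl group but joins them differently, and in this assay this gives a number 2 percentage points lower from compound 1 to compound 4 (within the scatter), so this position accepts two methyl groups on the phenyl ring as well as a single ethyl or chloro group without a step beyond the scatter. Going by these compounds alone, compound 4 also stays within the scatter of both chloro analogues, with a number 5 percentage points higher from compound 3 to compound 4 (within the scatter) and a number 8.9 percentage points higher from compound 2 to compound 4 (within the scatter), which leaves a number 10.9 percentage points lower from compound 1 to compound 2 (beyond the scatter) as the only step beyond the scatter and gives this small difference little weight as a trend among the aryl groups. No evidence at hand bears on the reason for these numbers.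

Going by these compounds, all four aryl groups carry only alkyl or chloro substituents, so it remains open whether an amine, a carboxylic acid or a longer chain on that phenyl ring would produce a step beyond the scatter. The trifluoromethyl group and both hydroxyl groups are also common to all four compounds, so their contribution to the read-out cannot be judged from this set.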